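Amide variation on the thienopyridine carboxamide series

The source may hold more compounds than are shown below. What is called first, only, known or untested is meant among the compounds shown, and "the series" means these compounds.

Compound 2 `Cc1ccc(C(=O)Nc2sc3c(c2C(N)=O)CCN(C(=S)Nc2ccccc2Cl)C3)cc1` is the reference for this step. In a functional assay on MKN-74 cells (Homo sapiens) for antiproliferative activity, with a stated time of 24 h (a higher number here means a weaker inhibitor, a lower number a stronger inhibitor), compound 2 gives 11300 nM, the lower of the two numbers recorded so far, with compound 1 `NC(=O)c1c(NC(=O)c2ccccc2Br)sc2c1CCN(C(=S)Nc1ccccc1Cl)C2` close by. In this assay compound 1 gives 12900 nM, and the step of a 1.1-fold lower number from compound 1 to compound 2 (0.06 log units; within the scatter) lies within the scatter, so the two compounds are not distinguished by this read-out.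

Compound 3 `NC(=O)c1c(NC(=O)c2ccncn2)sc2c1CCN(C(=S)Nc1ccccc1Cl)C2` carries the change (pyrimidin-4-yl in place of 4-methylphenyl on a carbonyl carbon). Within the data shown here, no measured pair covers the entry of a ring with hetero atoms at this position; the only step recorded, a 1.1-fold lower number from compound 1 to compound 2 (0.06 log units; within the scatter), swaps one carbon-only aromatic ring for another and shows no movement beyond the scatter. Among the measured compounds shown here, the single comparison therefore gives no direction for the step to compound 3, and a step within the scatter is the expectation, with widened uncertainty for an untested ring type.

For compound 3 the estimated value in this assay is 12000 nM, with an expected range from 4000 nM to 36000 nM, corresponding to an expected step of a 1.1-fold higher number from compound 2 to compound 3 (0.03 log units; within the scatter).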

Compound 3, half-maximal inhibitory concentration: 28400 nM
Compound 3: the middle estimate sits 2.4-fold (0.37 log units) below what was measured; the range from low to high includes it.
By their numbers in this assay, from the lowest: compounds 2 and 1 (each within the scatter of the next); then compound 3.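

In this assay, the place on the carbonyl carbon now shows a response to the ring it carries: pyrimidin-4-yl gives a 2.5-fold higher number from compound 2 to compound 3 (0.40 log units; beyond the scatter) and a 2.2-fold higher number from compound 1 to compound 3 (0.34 log units; beyond the scatter), whereas the exchange of one carbon-only ring for another stayed within the scatter (a 1.1-fold lower number from compound 1 to compound 2 (0.06 log units; within the scatter)). Both steps are modest, yet they point the same way, so among these three compounds the one six-membered aromatic ring with 2 hetero atoms stands apart from the two carbon-only rings, with the higher number. Nothing measured here bears on the reason for this shift.

Compound 3 differs from compound 1 and compound 2 both in its ring atoms and in lacking the methyl or bromo group, so the compounds shown cannot separate the effect of the ring nitrogens from the loss of that substituent. Open as well is whether a pyridine ring with a single nitrogen would fall with the carbon-only rings or with pyrimidin-4-yl, and how a phenyl ring bearing an amine or a carboxylic acid, or a saturated ring such as piperidine, would read at this place.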